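The source may report more compounds than this note shows. Statements on the series, on what has been measured and on what is new or still open speak of the compounds shown alone.

Measured so far:
- compound 1, `COCCN1C(=O)CNc2ncc(-c3ccc(C(C)(C)O)nc3)nc21`: 84% in a functional assay on the whole organism (PC-3 cells) for inhibition, with Mus musculus as the target, in a xenograft, with a stated time of 8 h, at a dose of 100 mg/kg by the oral route; on this read-out lower numbers stand for less inhibition and higher numbers for more inhibition at the one dose given (going by the name of the read-out)
- compound 2, `CO[C@H]1CC[C@@H](N2CC(=O)Nc3ncc(-c4ccc(C(C)(C)O)nc4)nc32)CC1`: 59%

Compound 1 stands highest of the two numbers; compound 2 comes nearest, a number lower by more than the usual scatter, so the two values do differ. Within the data shown here, no single-point step between these two is set out, so nothing beyond the two values themselves can be read from that pair.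

The unmeasured compound 3, `CO[C@H]1CC[C@H](N2C(=O)CNc3ncc(-c4ccc(C(C)(C)O)nc4)nc32)CC1`, differs from compound 1 in one place: 4-methoxycyclohexyl in place of 2-methoxyethyl on an amide-type nitrogen in a ring. A comparable methoxycyclohexyl group is present in compound 2, which gives a lower number than compound 1, so a drop seems more likely than a rise, though the rest of compound 2 is not arranged the same way as in compound 3. The step of a number 14 percentage points lower from compound 1 to compound 3 (beyond the scatter) is expected to be modest and downward. Compound 3 is estimated at 70%, within a range of 50% to 88%.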

Compound 3, a percentage reported as inhibition, in the whole organism at one dose (the size of the read-out at that dose, not a potency): 82%
For compound 3 the middle estimate is 12 percentage points below the measured one; the measured number falls inside the stated range.
By their numbers in this assay, from the lowest: compound 2; then compounds 3 and 1 (each within the scatter of the next).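

In this assay, putting 4-methoxycyclohexyl in place of 2-methoxyethyl on the amide-type nitrogen in a ring gives a number 2 percentage points lower from compound 1 to compound 3 (within the scatter) at this one dose. This nitrogen therefore carries a larger group, with a six-membered non-aromatic ring of carbon only instead of an open chain, and the two compounds cannot be told apart on this read-out. Nothing measured here explains why the two compounds read alike.

As far as these compounds go, what remains open is how this position would respond to a group of a different kind, such as an amine, a carboxylic acid or a longer chain. From the compounds shown here alone, it is also open whether the 4-methoxycyclohexyl group would read the same with a hydroxyl in place of its methoxy.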